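One Methoxy Added: Expectations for Compound 4

A few compounds are considered here, and "the series" means these few. Any claim that something is new, unique, unknown or untested is made for them only; others in the source may bear on it.

Compound 1 `COc1ccc(-c2nc3cc(C(C)O)ccc3[nH]2)c(OC)c1` and compound 2 `COc1ccc(-c2nc3cc(C(C)O)ccc3[nH]2)c(OC)c1OC` share a core; the difference between this core and that of compound 3 `COc1ccc(-c2nc3cc(/C(C)=N/NC(N)=S)ccc3[nH]2)cc1` is not broken down here. Compound 4 `COc1ccc(-c2nc3cc(/C(C)=N/NC(N)=S)ccc3[nH]2)c(OC)c1` has not yet been measured. In an ADME assay on Vero cells (Chlorocebus sabaeus) for cytotoxicity, read by MTT assay, with a stated time of 96 h (on this read-out higher numbers stand for lower toxicity in this test and lower numbers for higher toxicity in this test), compound 1 gives > 100000 nM, a limit of the assay rather than a number. Compound 2 gives >= 100000 nM, also a limit. Compound 3 gives > 100000 nM, again a limit. The change methoxy in place of hydrogen on an aromatic carbon gave a step that the two limits leave unreadable from compound 1 to compound 2, unreadable because of the limit of > 100000 nM in this assay, at which 2 of the 3 values shown sit, and (the limit of >= 100000 nM in this assay, at which 1 of the 3 values shown sits). The change methoxy in place of hydrogen on an aromatic carbon is the same kind of change, though its place is ortho to a large group and meta to a methoxy group, whereas in compound 2 it is ortho to two methoxy groups and meta to a large group. Since compound 1 and compound 2 both sit at limits, the step expected for compound 4 is a number no higher from compound 3 to compound 4 (the limit leaves the size open). Compound 4 is therefore estimated at 100000 nM.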

Compound 4, half-maximal cytotoxic concentration: > 100000 nM
Compound 4 gave a limit, no number; the forecaster's own chance of this, stated with the estimate: 85%; the middle value lies on the limit itself.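

Compound 1, compound 3 and compound 4 all sit at a limit of this assay, so no step to compound 4 can be read: the limit of > 100000 nM in this assay, at which 3 of the 4 values shown sit.

The compounds shown leave open whether methoxy in place of hydrogen changes toxicity at all.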